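A few compounds are considered here, and "the series" means these few. Any claim that something is new, unique, unknown or untested is made for them only; others in the source may bear on it.

Three compounds share one core and differ only in the group carried on the carbonyl carbon of the amide. Compound 1 `CCC(=O)N1CC2CC(C1)N2` carries an ethyl there; in an assay on SH-EP1 cells for agonist activity at Neuronal acetylcholine receptor; alpha4/beta2 (Homo sapiens), read by FLIPR and calcium flux (a higher number here means that more compound is needed for the effect, a lower number that less compound is needed), compound 1 gives 490 nM. Compound 2 `O=C([C@H]1C[C@H]1F)N1CC2CC(C1)N2` and compound 3 `O=C([C@@H]1C[C@@H]1F)N1CC2CC(C1)N2` both carry a 2-fluorocyclopropyl in place of the ethyl and are drawn with opposite configurations at the two ring stereocentres. In this assay compound 2 gives 210 nM and compound 3 gives 120 nM. Replacing the ethyl by the 2-fluorocyclopropyl lowers the number in both cases, a 2.3-fold lower number from compound 1 to compound 2 (0.37 log units; beyond the scatter) and a 4.1-fold lower number from compound 1 to compound 3 (0.61 log units; beyond the scatter), whereas the two drawn configurations lie within the scatter of each other a 1.8-fold lower number from compound 2 to compound 3 (0.24 log units; within the scatter). Compound 3 thus stands at the low end of the three numbers, but only its distance from compound 1 is a real difference; against compound 2 it cannot be separated.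

Compound 4 `C[C@@H]1C[C@@H]1C(=O)N1CC2CC(C1)N2` keeps a three-membered ring on the carbonyl carbon but swaps what the ring carries: a group of 4 heavy atoms (4 carbon; one three-membered non-aromatic ring of carbon only) in place of a group of 4 heavy atoms (3 carbon, 1 fluorine; one three-membered non-aromatic ring of carbon only), on a carbonyl carbon. Going by the values given here, no measured step exchanges fluorine for carbon on such a ring; the measured steps show only that a three-membered ring in this position does better than an ethyl. Compound 4 is therefore expected to sit near compound 3. The step of a 1.3-fold higher number from compound 3 to compound 4 (0.12 log units; within the scatter) is expected to stay within the scatter. In this assay compound 4 is estimated at 160 nM, with a range from 60 nM to 450 nM.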

Compound 4, half-maximal effective concentration: 2100 nM
Compound 4: middle estimate off by 13-fold (1.12 log units), on the low side; measured number above the stated range.
By their numbers in this assay, from the lowest: compounds 3 and 2 (each within the scatter of the next); then compound 1; then compound 4.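

At this position, on a carbonyl carbon, a three-membered ring is not enough by itself: what the ring carries matters a great deal, and in this assay methyl in place of fluoro gives an 18-fold higher number from compound 3 to compound 4 (1.24 log units; beyond the scatter) and a 10-fold higher number from compound 2 to compound 4 (1.00 log units; beyond the scatter). The earlier compounds shown here suggested that a ring here does better than an ethyl, but that holds only for the 2-fluorocyclopropyl of compounds 2 and 3, and the methyl-bearing ring goes against it, with a 4.3-fold higher number from compound 1 to compound 4 (0.63 log units; beyond the scatter). Nothing shown gives a reason why this exchange on the ring costs so much.

As far as these compounds go, it remains open whether fluorine is what helps or methyl is what harms: a plain cyclopropyl with neither group, or a ring bearing chlorine or a hydroxyl group in the same place, would help to separate the two readings. From the compounds shown here alone, only one drawn configuration of the methyl-bearing ring appears here, so it is also open whether the opposite configuration would stay as close to compound 4 as compounds 2 and 3 stay to each other.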